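A few compounds are considered here, and "the series" means these few. Any claim that something is new, unique, unknown or untested is made for them only; others in the source may bear on it.

Measured so far:
Compound 1 `CCn1nc(C)cc1C(=O)Nc1nc2cc(C(N)=O)cc(OC)c2n1CCCNC(=O)OCc1ccccc1`: > 100000 nM
Compound 2 `CCCn1c(NC(=O)c2nccc3ccccc23)nc2cc(C(N)=O)cc(OC)c21`: > 100000 nM
Compound 3 `COc1cc(C(N)=O)cc2nc(NC(=O)c3ccc4ccccc4n3)n(CCCNC(=O)OCc3ccccc3)c12`: > 100000 nM

In an assay for activation of interferon regulatory factor 3 (Homo sapiens), read by a luciferase reporter, with a stated time of 20 h (on this read-out lower numbers stand for an effect already at smaller amounts and higher numbers for an effect only at larger amounts of compound), compound 1 gives > 100000 nM, which is a limit of the assay and not a number. In this assay compound 2 gives > 100000 nM, again only a limit. Compound 3 likewise gives > 100000 nM in this assay, once more a limit. All three values sit at the same limit, namely (the limit of > 100000 nM in this assay, at which 3 of the 3 values shown sit), so no order among them can be read.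

Among the measured compounds shown here, the one step between measured compounds that differ in a single place is a step that the two limits leave unreadable from compound 1 to compound 3; with both ends at the limit, its size cannot be read.

Compound 4 `COc1cc(C(N)=O)cc2nc(NC(=O)c3nccc4ccccc34)n(CCCNC(=O)OCc3ccccc3)c12` differs from compound 3 by isoquinolin-1-yl in place of quinolin-2-yl on a carbonyl carbon. The measured steps give no readable size for any change at this position, and compound 3 shows only a limit. Compound 4 is therefore expected to stay at the limit as well, meaning a step that the limit leaves unreadable from compound 3 to compound 4, with the estimate 150000 nM between 30000 nM and 1000000 nM.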

Compound 4, half-maximal effective concentration: > 100000 nM
Compound 4 was reported as a limit; the forecaster's own chance of this, stated with the estimate: 85%; the middle value is on the limit's open side.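

Among the compounds shown here, no step to compound 4 from compound 1, compound 2 or compound 3 can be read in this assay, and all four values are limits of the assay, not numbers: the limit of > 100000 nM in this assay, at which 4 of the 4 values shown sit.

The compounds shown leave open how these four rank against each other, and which group on the carbonyl carbon, if any, would give a readable value.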